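From 3-hydroxyphenyl to phenyl in compound 3

A few compounds are considered here, and "the series" means these few. Any claim that something is new, unique, unknown or untested is made for them only; others in the source may bear on it.

Measured so far in a functional assay on PC-3 cells (Homo sapiens) for inhibition, read by MTT assay (on this read-out higher numbers stand for weaker inhibition and lower numbers for stronger inhibition), for this series:
- compound 1 `COc1c(N2CCN(C)CC2)c(F)cc2c(=O)c(C(=O)N/N=C\c3ccc(O)cc3)cn(C3CC3)c12` gives 14.4 ug/mL
- compound 2 `COc1c(N2CCN(C)CC2)c(F)cc2c(=O)c(C(=O)N/N=C\c3cccc(O)c3)cn(C3CC3)c12` gives 3.4 ug/mL

Compound 2, at 3.4 ug/mL in this assay, holds the lower of the two numbers. The next structure is compound 3 `COc1c(N2CCN(C)CC2)c(F)cc2c(=O)c(C(=O)N/N=C\c3ccccc3)cn(C3CC3)c12`, reached through (hydrogen in place of hydroxy on an aromatic carbon), that is, hydrogen in place of hydroxy on an aromatic carbon, or 3-hydroxyphenyl to phenyl.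

Going by the values given here, only one measured step bears on this. Placing 3-hydroxyphenyl where 4-hydroxyphenyl stood gave a 4.2-fold lower number from compound 1 to compound 2 (0.63 log units; beyond the scatter), a modest step that shows the number responding to where the hydroxy sits. Among the compounds with values here, no measured pair removes a hydroxy outright, so direction and size remain uncertain. From the compounds shown here alone, with neither hydroxyphenyl group present, a number between those of the two measured compounds is expected, though a wide range stays open. The estimated change is a 2.2-fold higher number from compound 2 to compound 3 (0.34 log units; beyond the scatter), which would be a modest move to weaker inhibition. For compound 3 the estimated value is 7.5 ug/mL, with an expected range from 2.5 ug/mL to 22 ug/mL as the outer ends.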

Compound 3, half-maximal inhibitory concentration: 16.3 ug/mL
For compound 3 the middle estimate is 2.2-fold (0.34 log units) below the measured one, and the stated range covers the measured number.
By their numbers in this assay, from the lowest: compound 2; then compounds 1 and 3 (each within the scatter of the next).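

Working notes on the hydroxy position, in this assay: on the 3-hydroxyphenyl group, hydrogen in place of hydroxy gives a 4.8-fold higher number from compound 2 to compound 3 (0.68 log units; beyond the scatter) and thus a clear move to weaker inhibition. The same replacement on the 4-hydroxyphenyl group gives a 1.1-fold higher number from compound 1 to compound 3 (0.05 log units; within the scatter) and so leaves no distinction between those two compounds on this read-out. Among these three compounds, the hydroxy therefore goes with stronger inhibition only in the 3-hydroxyphenyl placement, whereas the 4-hydroxyphenyl group cannot be told apart from plain phenyl.

Nothing available here accounts for this dependence on placement.

From the compounds shown here alone, it remains open whether the hydroxy itself is required, since a methoxy, an amine or a carboxylic acid on the same aromatic carbon could either hold the number of compound 2 or fall back to that of compound 3. Going by these compounds, it also remains open whether the same placement dependence would hold with a different group in place of the 4-methylpiperazine on the shared core.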